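The source may hold more compounds than are shown below. What is called first, only, known or untested is meant among the compounds shown, and "the series" means these compounds.

Two members of one series have been tested in an ADME assay on Vero cells (Chlorocebus sabaeus) for cytotoxicity, read by XTT assay, with a stated time of 72 h; a lower number here means that less compound is tolerated, a higher number that more compound is tolerated. Compound 1, `CC1=C(C(=O)Nc2ccccc2Cl)C(c2ccccc2Br)NC(=O)N1`, gives only a limit in this assay: > 100000 nM. Compound 2, `CC1=C(C(=O)Nc2ccccc2Cl)C(c2cccc([N+](=O)[O-])c2)NC(=O)N1`, is reported in this assay as "non-toxic" (no number reported), with no number attached. Compound 2 thus stands without a single value of its own. The other value shown is the limit of > 100000 nM in this assay, at which 1 of the 2 values shown sits, and it belongs to compound 1. Compound 3, `COc1cccc(C2NC(=O)NC(C)=C2C(=O)Nc2ccccc2Cl)c1`, is not yet measured. The change from compound 2 to compound 3 is methoxy in place of nitro on an aromatic carbon. For the measured compounds named here, no measured step of this kind exists, so no shift beyond the usual scatter is expected in this assay, in either direction, and a limit rather than a number seems the more likely outcome. Compound 3 is expected to give about 100000 nM in this assay, within a range from 50000 nM to 200000 nM.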

Compound 3, half-maximal cytotoxic concentration: > 100000 nM
Compound 3: a limit, no number; the forecaster's own chance of this, stated with the estimate: 80%; the middle value lies on the limit itself.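

Compound 1 and compound 3 each give a limit rather than a number, so no step between them can be read: the limit of > 100000 nM in this assay, at which 2 of the 3 values shown sit.

Going by these compounds, what stays open is the concentration, if any, at which compound 1, compound 2 or compound 3 would harm these cells.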